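Ring-to-chain swap on the aromatic nitrogen: compound 4

The compounds below may be only part of what the source reports. "The series", "measured", "known", "first", "only" and "open" are said of these compounds alone.

Compound 2 `Cc1cc(NC(=O)Cn2nnc(-c3ccccc3)n2)n(C2CCOCC2)n1` holds the highest of the three numbers in an assay on HEK293 cells for activation of Kir3.1/Kir3.2 (Homo sapiens), read by thallium flux (a lower number here means a smaller maximal response, a higher number a larger maximal response), giving 115%. Compound 1 `Cc1cc(NC(=S)Cn2nnc(-c3ccccc3)n2)n(C2CCCCC2)n1` gives 80% in this assay, and compound 3 `Cc1cc(NC(=O)Cn2nnc(-c3ccccc3)n2)n(C2CCC(F)(F)CC2)n1` gives 68%; both lie beyond the scatter below compound 2. For the measured compounds named here, compound 1 differs from compound 2 in two places, so no single step is drawn from it.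

Compound 4 `CCC(C)n1nc(C)cc1NC(=O)Cn1nnc(-c2ccccc2)n1` differs from compound 2 as follows: sec-butyl in place of oxan-4-yl on an aromatic nitrogen. Going by the values given here, the one measured step that bears on this place is the exchange on the same aromatic nitrogen, a number 47 percentage points lower from compound 2 to compound 3 (beyond the scatter), a large loss when the oxan-4-yl ring is replaced. Compound 4 likewise loses the oxan-4-yl and its ring, so a step downward is expected in this assay, though a smaller one than that seen with compound 3 is plausible, since the entering sec-butyl is a chain rather than a second ring. Compound 4 is therefore expected to give 85%, within 55% to 115%, meaning an expected step of a number 30 percentage points lower from compound 2 to compound 4 (beyond the scatter).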

Compound 4, largest response reached (Emax), in percent of the reference or control that the assay uses: > 69%
Compound 4: only a limit was reported; the forecaster's own chance of this, stated with the estimate: 0%; the middle value is on the limit's open side.
By their numbers in this assay, from the lowest: compound 3; then compound 1; then compound 2.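

Compound 4 carries only a limit in this assay, > 69%, and the reading of this position rests on it: the limit of > 69% in this assay, at which 1 of the 4 values shown sits.

Even so, the position on the aromatic nitrogen now accepts a group with no ring, since sec-butyl is the first chain there and the response reaches that limit, so a six-membered ring on this nitrogen is not required for a response of this order. Against the difluorinated ring the result is a number at least 1 percentage points higher from compound 3 to compound 4 (that floor lies within the scatter), so sec-butyl is not separated from 4,4-difluorocyclohexyl, and the step from the oxan-4-yl compound cannot be read.

From the compounds shown here alone, whether sec-butyl falls short of oxan-4-yl at all therefore stays open. Also open, going by these compounds, is how the response in this assay moves with a longer chain, such as n-hexyl, or with an amine, such as piperidin-4-yl, on this nitrogen.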